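The source may hold more compounds than are shown below. What is called first, only, known or untested is meant among the compounds shown, and "the series" means these compounds.

Compound 1 `CCCc1ccc(NC2=CC(=O)c3nc4n(c3C2=O)[C@H]2OC[C@@H](O)[C@H]2OC4)cc1` is tested in a functional assay on MCF7 cells (Homo sapiens) for inhibition, read by sulforhodamine B assay (a lower number here means a stronger inhibitor, a higher number a weaker inhibitor), where compound 1 gives 4660 nM. Compound 2 `Cc1ccc(NC2=CC(=O)c3c(nc4n3[C@H]3OC[C@@H](O)[C@H]3OC4)C2=O)cc1C` carries a 3,4-dimethylphenyl on the amine nitrogen, and in this assay compound 2 gives 4950 nM, which sits within the scatter of the number for compound 1, so the two cannot be told apart. Compound 3 `O=C1C(Nc2ccc(C(F)(F)F)cc2)=CC(=O)c2c1nc1n2[C@H]2OC[C@@H](O)[C@H]2OC1` bears a 4-(trifluoromethyl)phenyl in place of the 3,4-dimethylphenyl, and in this assay compound 3 reaches only a limit of the assay, > 4000 nM. Among the measured compounds shown here, the one step the data hold, a step that the limit leaves unreadable from compound 2 to compound 3, cannot be read because the limit of > 4000 nM in this assay, at which 1 of the 3 values shown sits, hides its size.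

Compound 4 `O=C1C=C(Nc2ccc(Br)cc2)C(=O)c2c1nc1n2[C@H]2OC[C@@H](O)[C@H]2OC1` differs from compound 1 by bromo in place of propyl on an aromatic carbon. For the measured compounds named here, no measured step exchanges a propyl for a bromo, so nothing here predicts the direction of the change; the only comparable exchange ends at a limit. The account therefore expects a step of a 1.2-fold higher number from compound 1 to compound 4 (0.07 log units; within the scatter) that is small and lies within the scatter, with some chance that compound 4 also returns only a limit. Compound 4 is estimated at 5500 nM in this assay, with a range from 2500 nM to 12000 nM.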

Compound 4, half-maximal inhibitory concentration: 2580 nM
Compound 4: middle estimate off by 2.1-fold (0.33 log units), on the high side; low and high end bracket the measured number.
By their numbers in this assay, from the lowest: compounds 4, 1 and 2 (each within the scatter of the next).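

In this assay, bromo in place of propyl on the aromatic carbon gives a 1.8-fold lower number from compound 1 to compound 4 (0.26 log units; within the scatter), so this position accepts the exchange of the 4-propylphenyl for the 4-bromophenyl, with fewer heavy atoms in the group, without a change that can be told from the scatter. With compound 4 added, compounds 4, 1 and 2 stand each within the scatter of the next, so the 4-bromophenyl, the 4-propylphenyl and the 3,4-dimethylphenyl cannot be ranked on these numbers. Whether the 4-(trifluoromethyl)phenyl of compound 3 fits this picture cannot be read, because its value is a limit and not a number: the limit of > 4000 nM in this assay, at which 1 of the 4 values shown sits.

The compounds shown leave open whether an amine, a carboxylic acid or a chain longer than propyl on this aromatic ring would move the number beyond the scatter. They also leave open whether any exchange on the shared core, rather than on the aromatic ring, would do so.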